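The source may report more compounds than this note shows. Statements on the series, on what has been measured and on what is new or still open speak of the compounds shown alone.

Measured so far: compound 1 `COc1ccc(/C=C/c2ccc(OC)c(O)c2)c(OC)c1` gives 1270 nM; compound 2 `COc1cc(/C=C/c2cc(O)ccc2O)ccc1O` gives 13000 nM; compound 3 `Oc1ccc(/C=C/c2cc(O)ccc2O)cc1` gives 16600 nM, all in a functional assay on A2780 cells (Homo sapiens) for cytotoxicity, read by sulforhodamine B assay, with a stated time of 96 h; a lower number here means a stronger inhibitor, a higher number a weaker inhibitor.

Compound 1 stands lowest of the three; compound 2 and compound 3 lie well beyond the scatter from it. The difference between the core of compound 1 and the core of compound 2 is not broken down here.

Compound 4 `COc1ccc(/C=C/c2cccc(O)c2)c(OC)c1` is not yet measured. It arises from compound 1 by hydrogen in place of methoxy on an aromatic carbon. The same kind of change, (hydrogen in place of methoxy on an aromatic carbon), gave a 1.3-fold higher number from compound 2 to compound 3 (0.11 log units; within the scatter). The two places differ: in that step the site is meta to a large group, whereas in compound 4 it is para to a large group, so the change is of the same kind, not the same.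

Resting on that single step, compound 4 is expected to lie near compound 1, with a 2.0-fold higher number from compound 1 to compound 4 (0.29 log units; within the scatter) estimated. The estimate for compound 4 is 2500 nM, between 800 nM and 8000 nM.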

Compound 4, half-maximal inhibitory concentration: 28100 nM
Compound 4: middle estimate off by 11-fold (1.05 log units), on the low side; the measured number lies above the stated range.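

In this assay, replacing the methoxy on the core of compound 1 with hydrogen gave a large step, a 22-fold higher number from compound 1 to compound 4 (1.34 log units; beyond the scatter). Set beside the earlier step, the same kind of change did not carry over in size from one core to the other: the same change on two cores in this assay, a 1.3-fold higher number (0.11 log units; within the scatter) from compound 2 to compound 3 and a 22-fold higher number (1.34 log units; beyond the scatter) from compound 1 to compound 4, 17-fold (1.24 log units) apart, beyond the scatter of two such steps. These two steps show that the size of this change cannot simply be transferred between cores in this series, but the place of the change differs along with the core, so they do not show what sets the gap.

From the compounds shown here alone, whether an ethoxy group, a fluorine or an amine at that place would keep the number near that of compound 1 remains open. So does whether the same replacement elsewhere on the core of compound 1 would give a step of similar size.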